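From hydroxy to chloro: does toxicity appear?

A few compounds are considered here, and "the series" means these few. Any claim that something is new, unique, unknown or untested is made for them only; others in the source may bear on it.

Compound 1 `O=C1Nc2ccccc2/C1=N/NC(=S)N1CCN(C(=O)NO)CC1` gives > 100000 nM
Compound 2 `O=C(NO)N1CCN(C(=S)N/N=C/c2ccccc2O)CC1` gives > 100000 nM

In a functional assay on HCT-116 cells (Homo sapiens) for cytotoxicity, read by MTT assay, with a stated time of 48 h (on this read-out higher numbers stand for lower toxicity in this test and lower numbers for higher toxicity in this test), compound 2 stands at > 100000 nM as a limit of the assay, not a number. Compound 3 `O=C(NO)N1CCN(C(=S)N/N=C/c2ccccc2Cl)CC1` differs from it by chloro in place of hydroxy on an aromatic carbon on the ring: chloro in place of hydroxy on an aromatic carbon, ortho to a large group. Among the compounds with values here, no measured pair shows such a change, so the only guide is the limit of > 100000 nM in this assay, at which 2 of the 2 values shown sit, and in this assay a small move toward lower numbers is expected, or none beyond the scatter. The expected step of an at least 1.2-fold lower number from compound 2 to compound 3 (0.09 log units; that floor lies within the scatter) is modest. For compound 3 the estimate is 80000 nM, with an expected range from 20000 nM to 200000 nM.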

Compound 3, concentration lethal to 50% of the cells: > 100000 nM
Compound 3: a limit, no number (the forecaster's own chance of this, stated with the estimate: 70%); middle value at least 1.2-fold (0.09 log units) from the limit.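

Compound 2 and compound 3 both give a limit of the assay rather than a number, so no step can be read between them: the limit of > 100000 nM in this assay, at which 3 of the 3 values shown sit.

The compounds shown leave open whether chloro in place of hydroxy changes toxicity at all.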